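The source may hold more compounds than are shown below. What is called first, only, known or untested is meant among the compounds shown, and "the series" means these compounds.

Measured compounds in a functional assay on DLD-1 cells (Homo sapiens) for antiproliferative activity, read by CellTiter-Glo, with a stated time of 72 h; a higher number here means a weaker inhibitor, a lower number a stronger inhibitor:

Compound 1 `COc1ccccc1-c1cccc(S(=O)(=O)N2CCC(N3CCC(C)CC3)CC2)c1` — 21 nM
Compound 2 `CC1CCN(C2CCN(S(=O)(=O)c3cn(C)cn3)CC2)CC1` — > 5000 nM, which is a limit of this assay and not a number.
Compound 3 `CCc1ccc(S(=O)(=O)N2CCC(N3CCC(C)CC3)CC2)cc1` — > 5000 nM, which is a limit of this assay and not a number.

Within the data shown here, compound 1 is the only member of the series with a numerical value in this assay; the other two values sit at the limit of > 5000 nM in this assay, at which 2 of the 3 values shown sit. Its place in the series therefore cannot be ranked against the others beyond saying that it gives a number where they do not.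

Compound 4 `CC1CCN(C2CCN(S(=O)(=O)c3cccc(-c4ccc(Cl)cc4)c3)CC2)CC1` is not yet measured. It differs from compound 1 in one place: 4-chlorophenyl in place of 2-methoxyphenyl on an aromatic carbon.

Among the measured compounds shown here, the only measured step, a step that the two limits leave unreadable from compound 2 to compound 3, concerns the group on the sulfonyl sulfur, not the aromatic carbon changed here, and both of its values are limits, so its size is not readable. For the measured compounds named here, no measured step bears directly on an exchange of 2-methoxyphenyl for 4-chlorophenyl. Compound 1 carries the biaryl arrangement that compound 4 keeps, while compounds 2 and 3 lack it; beyond that, nothing in the data constrains the step.

The expectation is that compound 4 stays close to compound 1, with the step of a 1.9-fold higher number from compound 1 to compound 4 (0.28 log units; within the scatter) small and not beyond the scatter. For compound 4 the estimated value in this assay is 40 nM, ranging from 10 nM to 250 nM.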

Compound 4, half-maximal inhibitory concentration: 15 nM
Compound 4: the middle estimate sits 2.7-fold (0.43 log units) above what was measured, and the stated range covers the measured number.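

In this assay, among these compounds, 4-chlorophenyl in place of 2-methoxyphenyl on this aromatic carbon gives a 1.4-fold lower number from compound 1 to compound 4 (0.15 log units; within the scatter), the first step that can be read as a number, and the two compounds cannot be told apart. The position therefore holds activity with either aryl group, so the methoxy oxygen is not required here as long as 4-chlorophenyl takes its place, and the substitution pattern of the outer ring can change without a step beyond the scatter. Compound 2 and compound 3 still give no number to set against this pair, each value being a limit of the assay and not a number: the limit of > 5000 nM in this assay, at which 2 of the 4 values shown sit.

The compounds shown leave open how far this tolerance extends, for example to an unsubstituted phenyl, a pyridine ring, or an outer ring carrying a carboxylic acid or an amine. They also leave open whether the outer aryl ring is itself required at this aromatic carbon, since no pair here differs only by its removal, and no cause for the step can be drawn from them.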